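Ring exchange beside the sulfonamide nitrogen and permeability

The source may hold more compounds than are shown below. What is called first, only, known or untested is meant among the compounds shown, and "the series" means these compounds.

Of the compounds shown here, three have been measured in an ADME assay on MDCKII-LE cells (Canis lupus familiaris) for permeability, read by transwell migration, in the apical to basolateral direction; a higher number here means that the compound crosses the layer faster, a lower number that the compound crosses the layer more slowly. Compound 1 `NC(=O)[C@@H](CCC(F)(F)F)N(CC1COC1)S(=O)(=O)c1ccc(Cl)cc1` gives 25.4 10^-6 cm/s, compound 2 `CC1(C)CO[C@@H]1CN([C@H](CCC(F)(F)F)C(N)=O)S(=O)(=O)c1ccc(Cl)cc1` gives 22.3 10^-6 cm/s, and compound 3 `NC(=O)[C@@H](CCC(F)(F)F)N(CC1CCOCC1)S(=O)(=O)c1ccc(Cl)cc1` gives 26.3 10^-6 cm/s. Compound 2 stands with the other two inside the usual scatter: a 1.1-fold lower number from compound 1 to compound 2 (0.06 log units; within the scatter) and a 1.2-fold higher number from compound 2 to compound 3 (0.07 log units; within the scatter), as does a 1.0-fold higher number from compound 1 to compound 3 (0.02 log units; within the scatter). Compound 4 `NC(=O)[C@@H](CCC(F)(F)F)N(C[C@H]1COCCO1)S(=O)(=O)c1ccc(Cl)cc1` has not yet been measured in this assay. Its change from compound 2 is 1,4-dioxan-2-yl in place of 3,3-dimethyloxetan-2-yl on a saturated chain carbon bound to a sulfonamide nitrogen. Each measured step replaces the ring on the saturated chain carbon bound to the sulfonamide nitrogen, and none moved the number beyond the scatter, so no step beyond the scatter is expected here either. Compound 4 is therefore estimated at 23 10^-6 cm/s, within 15 10^-6 cm/s to 34 10^-6 cm/s, an expected step of a 1.0-fold higher number from compound 2 to compound 4 (0.01 log units; within the scatter).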

Compound 4, apparent permeability: 20.6 10^-6 cm/s
The estimate for compound 4 lay 1.1-fold (0.05 log units) above the measured number, and the stated range covers the measured number.
By their numbers in this assay, from the lowest: compounds 4, 2, 1 and 3 (each within the scatter of the next).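

Setting 1,4-dioxan-2-yl, with 2 hydrogen-bond acceptors, in place of 3,3-dimethyloxetan-2-yl, with 1 hydrogen-bond acceptor, gives in this assay a 1.1-fold lower number from compound 2 to compound 4 (0.03 log units; within the scatter). The other exchanges read alike, with a 1.3-fold lower number from compound 3 to compound 4 (0.11 log units; within the scatter) and a 1.2-fold lower number from compound 1 to compound 4 (0.09 log units; within the scatter), so all four rings on a saturated chain carbon bound to a sulfonamide nitrogen lie within the scatter of one another. Nothing available accounts for this result. From the compounds shown here alone, whether a group carrying an amine or a carboxylic acid at this place would stay within the scatter remains open.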